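Replacing pyridin-3-yl with 4-chloropyrimidin-2-yl on an amine

The source may report more compounds than this note shows. Statements on the series, on what has been measured and on what is new or still open speak of the compounds shown alone.

Compound 1 `C[C@@H](Cn1ccc(-c2ccc(C#N)c(Cl)c2)n1)NS(=O)(=O)c1cccnc1`: > 30000 nM
Compound 2 `C[C@@H](Cn1ccc(-c2ccc(C#N)c(Cl)c2)n1)Nc1cccnc1`: > 30000 nM

Compound 1 carries a (pyridin-3-yl)sulfonyl group on its amine nitrogen. In an ADME assay on PC-3 cells (Homo sapiens) for cytotoxicity, read by CCK-8 assay, with a stated time of 6 days (a higher number here means a weaker inhibitor, a lower number a stronger inhibitor), compound 1 reaches only the limit of the assay, > 30000 nM. Compound 2 replaces that group with pyridin-3-yl. In this assay compound 2 likewise gives only a limit, > 30000 nM. The step that the two limits leave unreadable from compound 1 to compound 2 therefore cannot be read, since both measurements share (the limit of > 30000 nM in this assay, at which 2 of the 2 values shown sit). Compound 2 thus stands at the limit of the numbers shown, with nothing to set it apart from compound 1.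

Compound 3 `C[C@@H](Cn1ccc(-c2ccc(C#N)c(Cl)c2)n1)Nc1nccc(Cl)n1` differs from compound 2 by 4-chloropyrimidin-2-yl in place of pyridin-3-yl on an amine nitrogen. Among the compounds with values here, no measured step covers this change, and the only step that exists between the measured compounds is unreadable. Nothing in the data points to a readable gain or loss, so the step that the limit leaves unreadable from compound 2 to compound 3 is expected to amount to no change beyond the scatter. Compound 3 is estimated at 40000 nM, within a range of 15000 nM to 100000 nM, and is expected most likely to be reported only as a limit again.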

Compound 3, half-maximal inhibitory concentration: > 30000 nM
Compound 3 was reported as a limit; the forecaster's own chance of this, stated with the estimate: 80%; the middle value does not contradict the limit.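

In this assay compound 3 gives only a limit, > 30000 nM. No step among compound 1, compound 2 and compound 3 can therefore be read: the limit of > 30000 nM in this assay, at which 3 of the 3 values shown sit.

The compounds shown leave open whether any of these changes on the amine nitrogen alters the read-out, and how the three compare with one another.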